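The source may hold more compounds than are shown below. What is called first, only, known or untested is meant among the compounds shown, and "the series" means these compounds.

Going by the values given here, in a functional assay on NCI-H460 cells (Homo sapiens) for cytotoxicity, read by sulforhodamine B assay (on this read-out higher numbers stand for lower toxicity in this test and lower numbers for higher toxicity in this test), the three compounds read so far on the shared core give no number, only limits. Compound 1 `CC1=CC[C@@H]([C@@](C)(O)CCCC(C)(C)NC(=S)NN)CC1` gives > 100000 nM, which is a limit of the assay. Compound 2 `CC1=CC[C@@H]([C@@](C)(O)CCCC(C)(C)NC(=S)N/N=C\c2ccccc2[N+](=O)[O-])CC1` gives > 100000 nM, again a limit. Compound 3 `CC1=CC[C@@H]([C@@](C)(O)CCCC(C)(C)NC(=S)N/N=C\c2cccc([N+](=O)[O-])c2)CC1` gives > 100000 nM, also a limit. It therefore stands with the others, as the summary shows: the limit of > 100000 nM in this assay, at which 3 of the 3 values shown sit.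

Compound 4 `CC1=CC[C@@H]([C@@](C)(O)CCCC(C)(C)NC(=S)N/N=C\c2cccc(Cl)c2)CC1` differs from compound 3 by one change, chloro in place of nitro on an aromatic carbon, meta to a large group: chloro in place of nitro on an aromatic carbon.

Among the compounds with values here, only one measured step bears on this change, and it moves the nitro group rather than replacing it: a step that the two limits leave unreadable from compound 2 to compound 3. Within the data shown here, both of its ends are limits, so it gives no size to carry over, and no measured step replaces nitro with anything else. The data therefore give no reason to expect a step beyond the scatter in this assay, and they give no direction for one. The most likely outcome is another limit, and the expected change is small: a number no higher from compound 3 to compound 4 (the limit leaves the size open). For compound 4 the estimate is 100000 nM, with an expected range from 40000 nM to 150000 nM.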

Compound 4, concentration lethal to 50% of the cells: > 100000 nM
Compound 4 gave a limit, no number; the forecaster's own chance of this, stated with the estimate: 75%; the middle value lies on the limit itself.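

In this assay compound 4 gives > 100000 nM, which is a limit of the assay and not a number. No new step can be read from compound 1, compound 2 or compound 3 to compound 4: the limit of > 100000 nM in this assay, at which 4 of the 4 values shown sit.

The compounds shown leave open whether 2-nitrophenyl, 3-nitrophenyl and 3-chlorophenyl differ at all, and they give no number for any of these compounds.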